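Working notes: the step from compound 3 to compound 4

The compounds below may be only part of what the source reports. "The series", "measured", "known", "first", "only" and "open" are said of these compounds alone.

Measured in a functional assay on DU-145 cells (Homo sapiens) for cytotoxicity, read by trypan blue exclusion, with a stated time of 96 h; on this read-out lower numbers stand for stronger inhibition and higher numbers for weaker inhibition:
- compound 1 `COc1ccc(NS(=O)(=O)/C=C/c2c(F)c(F)c(F)c(F)c2F)cc1[N+](=O)[O-]`: 100000 nM
- compound 2 `COc1ccc(/C=C/S(=O)(=O)Nc2c(F)c(F)c(F)c(F)c2F)cc1N`: 35000 nM
- compound 3 `COc1cc(OC)c(/C=C/S(=O)(=O)Nc2ccc(OC)c(OP(=O)(O)O)c2)c(OC)c1`: 40 nM

Compound 3 holds the lowest number of the three, and its gaps to compound 2 and to compound 1 both lie well beyond the scatter. Compound 4 `COC(=O)C(Nc1cc(NS(=O)(=O)/C=C/c2c(OC)cc(OC)cc2OC)ccc1OC)c1ccccc1` differs from compound 3 in one place: a group of 12 heavy atoms (9 carbon, 1 nitrogen, 2 oxygen; one six-membered aromatic ring of carbon only) in place of a group of 5 heavy atoms (4 oxygen, 1 phosphorus; no ring), on an aromatic carbon. The exchange sits on an aromatic carbon, ortho to a methoxy group and meta to a large group.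

Going by the values given here, no pair of measured compounds differs in one place, so the series offers no direct precedent for this change. Compound 4 keeps the core of compound 3, which stands at 40 nM, so a result nearer that value than the much higher numbers of compounds 1 and 2 is expected. A modest rise in this assay, towards weaker inhibition and beyond the scatter, is expected, with the estimated step being a 3.8-fold higher number from compound 3 to compound 4 (0.57 log units; beyond the scatter). For compound 4 the estimate is 150 nM, with an expected range of 20 nM to 2000 nM.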

Compound 4, half-maximal inhibitory concentration: 2500 nM
Estimate against measurement, compound 4: 17-fold (1.22 log units) below; the measured number lies above the stated range.
By their numbers in this assay, from the lowest: compound 3; then compound 4; then compound 2; then compound 1.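

Going by these compounds alone, this is the only one-place comparison, and it shows that the number in this assay depends strongly on the group held at this position. On an aromatic carbon ortho to a methoxy group, the group of 12 heavy atoms with its six-membered aromatic ring, in place of the group of 5 heavy atoms, gives a 63-fold higher number from compound 3 to compound 4 (1.80 log units; beyond the scatter), a large step well beyond the scatter. No measurement at hand bears on the cause of this step.

A single pair cannot separate the loss of the group of 5 heavy atoms from the arrival of the group of 12 heavy atoms. Whether the ring, the methyl ester or the linking nitrogen accounts for the higher number stays open, as does the effect of a hydroxyl group or a carboxylic acid on the same carbon.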